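The compounds below may be only part of what the source reports. "The series", "measured", "known", "first", "only" and "open" are said of these compounds alone.

Compound 1 `CN(Cc1ccc(F)cc1)c1cc(C(=O)Nc2ccccc2)ncn1`: < 5000 nM, which is a limit.
Compound 2 `COc1ccc(NC(=O)c2cc(N(C)Cc3cccc(F)c3)ncn2)cc1`: 5000 nM.
Compound 3 `COc1ccc(NC(=O)c2cc(N(C)Cc3ccc(F)cc3)ncn2)cc1`: 62000 nM.

In a physicochemical assay for solubility, using the shake flask method, measured as kinetic solubility, with a stated time of 2 h, at pH 7.4 (on this read-out higher numbers stand for higher solubility and lower numbers for lower solubility), compound 3 holds the higher of the two actual numbers, and compound 1 gives only a limit. The nearest number belongs to compound 2, and the gap is a 12-fold higher number from compound 2 to compound 3 (1.09 log units; beyond the scatter).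

Compound 4 `COCCOc1ccc(NC(=O)c2cc(N(C)Cc3ccc(F)cc3)ncn2)cc1` carries methoxymethyl in place of hydrogen on a saturated chain carbon bound to an oxygen on an aromatic ring, which turns methoxy into 2-methoxyethoxy (methoxymethyl in place of hydrogen on a saturated chain carbon bound to an oxygen on an aromatic ring).

The closest measured change is an at least 12-fold higher number from compound 1 to compound 3 (1.09 log units; beyond the scatter), with methoxy in place of hydrogen on an aromatic carbon. That step was large, but it rests on a limit and it only introduces the methoxy group. Among the measured compounds shown here, no measured step extends that group, so its size does not carry over to compound 4. The other step, a 12-fold higher number from compound 2 to compound 3 (1.09 log units; beyond the scatter), lies elsewhere in the molecule, but it shows that a single small change can move this read-out a long way.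

No shift beyond the scatter is therefore expected in this assay, and the expected step is a 1.1-fold higher number from compound 3 to compound 4 (0.05 log units; within the scatter). For compound 4 the estimated value is 70000 nM, with an expected range from 22000 nM to 200000 nM.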

Compound 4, solubility: < 5000 nM
Compound 4 ended at the assay's limit (the forecaster's own chance of this, stated with the estimate: 15%); middle value at least 14-fold (1.14 log units) away from the limit.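

In this assay, among the compounds shown here, adding methoxymethyl on the saturated chain carbon bound to an oxygen on an aromatic ring, which turns methoxy into 2-methoxyethoxy, gives an at least 12-fold lower number from compound 3 to compound 4 (1.09 log units; beyond the scatter), so this site responds strongly to extension of the group, which no earlier pair could show. The earlier steps shown here, an at least 12-fold higher number from compound 1 to compound 3 (1.09 log units; beyond the scatter) and a 12-fold higher number from compound 2 to compound 3 (1.09 log units; beyond the scatter), showed only the gain on introducing methoxy and the sensitivity to where the fluorine sits on the phenyl ring, and with this result compound 3 stands out among the four compounds, since a single change at either of two sites leaves a much lower number. The step from compound 1 to compound 4 joins two limits and cannot be read, and the step to compound 4 has a size that is itself only a bound, since compound 4 gives a limit and not a number: the limit of < 5000 nM in this assay, at which 2 of the 4 values shown sit.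

From the compounds shown here alone, how far the number for compound 4 lies past that limit stays open. Also open, going by these compounds, is whether the large step follows from the added chain length or from its terminal ether oxygen, which an ethoxy group, a propoxy group or a 2-aminoethoxy chain at the same site could separate.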